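Nitro for nitrile on two related amide cores

The source may report more compounds than this note shows. Statements on the series, on what has been measured and on what is new or still open speak of the compounds shown alone.

Three compounds have been measured in a functional assay on LNCaP cells (Homo sapiens) for antiproliferative activity, read by propidium iodide staining, with a stated time of 96 h; a higher number here means a weaker inhibitor, a lower number a stronger inhibitor:
compound 1 `CC(O)(COc1ccc(S(F)(F)(F)(F)F)cc1)C(=O)Nc1ccc(C#N)c(C(F)(F)F)c1` gives 11500 nM;
compound 2 `CC(O)(COc1ccc(S(F)(F)(F)(F)F)cc1)C(=O)Nc1ccc([N+](=O)[O-])c(C(F)(F)F)c1` gives 100000 nM;
compound 3 `CC(O)(COc1ccc(S(F)(F)(F)(F)F)cc1)C(=O)Nc1ccc(C#N)cc1C(F)(F)F` gives 12300 nM.

Compound 1 and compound 3 are built from the same atoms joined differently; the difference between the two cores is not broken down here. Their values in this assay lie within the scatter of each other.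

The change from compound 1 to compound 2 is nitro in place of cyano on an aromatic carbon. In this assay it produced an 8.7-fold higher number from compound 1 to compound 2 (0.94 log units; beyond the scatter).

Compound 4 `CC(O)(COc1ccc(S(F)(F)(F)(F)F)cc1)C(=O)Nc1ccc([N+](=O)[O-])cc1C(F)(F)F` has not yet been measured. It differs from compound 3 by nitro in place of cyano on an aromatic carbon. For the measured compounds named here, this is the same kind of change as the one from compound 1 to compound 2, but the surroundings are not identical: in compound 1 the group that leaves is ortho to a trifluoromethyl group, whereas in compound 3 it is meta to a trifluoromethyl group; in both it is para to a large group.

Going by the values given here, only one measured instance of this change exists, so the expectation rests on it alone. Since compound 1 to compound 2 gave an 8.7-fold higher number from compound 1 to compound 2 (0.94 log units; beyond the scatter), a step of similar size is expected from compound 3 to compound 4, namely a 7.3-fold higher number from compound 3 to compound 4 (0.86 log units; beyond the scatter). Compound 4 is therefore estimated at 90000 nM in this assay, with a range from 30000 nM to 300000 nM; the high end of this range lies where the assay may report only a limit.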

Compound 4, half-maximal inhibitory concentration: 14800 nM
Estimate against measurement, compound 4: 6.1-fold (0.78 log units) above; the measured number lies below the stated range.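

In this assay, the change from nitrile to nitro does not keep its size from one core to the other: the same change on two cores in this assay, an 8.7-fold higher number (0.94 log units; beyond the scatter) from compound 1 to compound 2 and a 1.2-fold higher number (0.08 log units; within the scatter) from compound 3 to compound 4, 7.2-fold (0.86 log units) apart, beyond the scatter of two such steps. On the core of compound 3 the change amounts to a 1.2-fold higher number from compound 3 to compound 4 (0.08 log units; within the scatter), so the nitrile and the nitro group give values within the scatter of each other there, whereas on the core of compound 1 the nitro group gives the clearly higher number. This shows that a step seen on one of these two cores cannot simply be carried to the other, but with one pair on each core it does not show which feature of the cores is responsible, though the cores differ in where the trifluoromethyl group stands on the anilide ring, nor does it show how the step would behave on any further core.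

The compounds shown leave open whether an amine, a chlorine atom or a carboxylic acid on the same aromatic carbon would also part ways between the two cores. They also leave open whether the difference between the two steps would persist if the pentafluorosulfanyl group on the other aromatic ring gave way to a trifluoromethyl group or a chlorine atom.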